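Chloro Added to a Benzylidene Ring: Two Cores Compared

A few compounds are considered here, and "the series" means these few. Any claim that something is new, unique, unknown or untested is made for them only; others in the source may bear on it.

Compound 1, `O=C1OC(c2ccc(Cl)cc2)=C/C1=C\c1ccccc1`, gives 36% in a functional assay on the whole organism (strain Wistar) for inhibition, with Rattus norvegicus as the target, with stated times of 30 min and 3 h, at a dose of 20 mg/kg by the oral route; a higher number here means more inhibition at the dose given (going by the name of the read-out), a lower number less inhibition. Compound 2, `O=C1OC(c2ccc(Cl)cc2)=C/C1=C\c1ccccc1Cl`, gives 81.5% in the same test. The two differ by chloro in place of hydrogen on an aromatic carbon, and that single change produced a number 45.5 percentage points higher from compound 1 to compound 2 (beyond the scatter).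

Compound 3, `O=C1/C(=C/c2ccccc2)C=C(c2ccc(Cl)cc2)N1Cc1ccccc1`, has a different core; the difference between the two cores is not broken down here. Compound 3 gives 37% in this assay, a number close to that of compound 1, and well below that of compound 2.

Compound 4, `O=C1/C(=C/c2ccc(Cl)cc2)C=C(c2ccc(Cl)cc2)N1Cc1ccccc1`, is not yet measured. It differs from compound 3 by chloro in place of hydrogen on an aromatic carbon. This is the same kind of change as that from compound 1 to compound 2, but not the same: in the earlier pair the chloro sits ortho to a large group, here it sits para to a large group. The expected step is a number 21 percentage points higher from compound 3 to compound 4 (beyond the scatter), kept smaller than the earlier one because a number 45.5 percentage points higher from compound 1 to compound 2 (beyond the scatter) was seen at a different place on the ring. Compound 4 is therefore estimated at 58%, between 35% and 82%.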

Compound 4, a percentage reported as inhibition, in the whole organism at one dose (the size of the read-out at that dose, not a potency): 88.9%
The estimate for compound 4 lay 30.9 percentage points below the measured number; the whole stated range lies below it.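

In this assay, the change from phenyl to 4-chlorophenyl, with the chloro para to a large group, gave a number 51.9 percentage points higher from compound 3 to compound 4 (beyond the scatter), so a large rise appears on the core of compound 3 as well as on the core of compound 1. Set side by side, the two steps do not differ in size: the same change on two cores in this assay, a number 45.5 percentage points higher (beyond the scatter) from compound 1 to compound 2 and a number 51.9 percentage points higher (beyond the scatter) from compound 3 to compound 4, 6.4 percentage points apart, within the scatter of two such steps. In these two pairs the gain carried over from one core to the other, even with the chloro at a different place on the ring, but two pairs make no rule for the whole series, and the reason for the rise remains unknown.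

The compounds shown leave open whether another group on this ring, such as methoxy or an amine, would give a similar rise. They also leave open what chloro at the same place on both cores would do, and whether the rise would hold at other doses.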